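Testing a Hydroxyphenyl Swap in a Cytotoxicity Series

The source may report more compounds than this note shows. Statements on the series, on what has been measured and on what is new or still open speak of the compounds shown alone.

Measured so far:
compound 1 `O=C(/C=C/c1ccc2c(c1)B(O)OC2)c1ccc(F)cc1`: 1400 nM
compound 2 `CCc1ccc(C(=O)/C=C/c2ccc3c(c2)B(O)OC3)cc1`: 4400 nM
compound 3 `O=C(/C=C/c1ccc2c(c1)B(O)OC2)c1ccc(C(F)(F)F)cc1`: 3700 nM

In a functional assay on SK-OV-3 cells (Homo sapiens) for cytotoxicity, read by MTT assay, with a stated time of 48 h (on this read-out higher numbers stand for weaker inhibition and lower numbers for stronger inhibition), compound 1 has the lowest number of the three. From it, a 3.1-fold higher number from compound 1 to compound 2 (0.50 log units; beyond the scatter) and a 2.6-fold higher number from compound 1 to compound 3 (0.42 log units; beyond the scatter), while between the other two a 1.2-fold lower number from compound 2 to compound 3 (0.08 log units; within the scatter). Compound 4 `O=C(/C=C/c1ccc2c(c1)B(O)OC2)c1ccccc1O` differs from compound 1 in one place: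
2-hydroxyphenyl in place of 4-fluorophenyl on a carbonyl carbon
The two measured steps each replace fluoro with another group on the ring attached to the carbonyl carbon, and both were modest rises in the number. Within the data shown here, no measured step puts a hydroxyl on that ring, so these steps bear on the change only loosely. A small rise, or none beyond the scatter, is therefore expected, namely a 1.4-fold higher number from compound 1 to compound 4 (0.15 log units; within the scatter). Compound 4 is estimated at 2000 nM, with a range from 700 nM to 6000 nM.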

Compound 4, half-maximal inhibitory concentration: 48800 nM
Compound 4: middle estimate off by 24-fold (1.39 log units), on the low side, and the stated range ends below it.
By their numbers in this assay, from the lowest: compound 1; then compounds 3 and 2 (each within the scatter of the next); then compound 4.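

In this assay the swap to 2-hydroxyphenyl gives a 35-fold higher number from compound 1 to compound 4 (1.54 log units; beyond the scatter) and so far exceeds the modest rises seen with ethyl and trifluoromethyl. This position on the carbonyl carbon is therefore far more sensitive to the group it carries than those earlier compounds suggested. The two groups also have the same number of heavy atoms, so that count alone does not predict the outcome, and nothing available accounts for the large step.

Fluoro leaves and hydroxyl enters in one change, so it remains open which of them matters. Plain phenyl, or a methoxy group in place of the hydroxyl, would help to separate the two.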